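A few compounds are considered here, and "the series" means these few. Any claim that something is new, unique, unknown or untested is made for them only; others in the source may bear on it.

Measured compounds:
compound 1 `CC(O)c1ccc(C(=O)N[C@@H](C)Cn2ccc(-c3ccc(C#N)c(Cl)c3)n2)cc1` with 3690 nM in a functional assay on LNCaP cells (Homo sapiens) for antiproliferative activity, read by CCK-8 assay, with a stated time of 6 days; a higher number here means a weaker inhibitor, a lower number a stronger inhibitor
compound 2 `CC(=O)c1ccc(C(=O)N[C@@H](C)Cn2ccc(-c3ccc(C#N)c(Cl)c3)n2)cc1` with 3600 nM in this assay

Compound 2 has the lowest of the two numbers in this assay, but its nearest neighbour is compound 1, and the step of a 1.0-fold lower number from compound 1 to compound 2 (0.01 log units; within the scatter) falls within the scatter, so the two are not distinguishable. That step swapped a 1-hydroxyethyl for an acetyl on an aromatic carbon and left the number essentially unchanged.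

Compound 3 `C[C@@H](Cn1ccc(-c2ccc(C#N)c(Cl)c2)n1)NC(=O)c1ccccc1F` arises from compound 2 by a different kind of change: 2-fluorophenyl in place of 4-acetylphenyl on a carbonyl carbon. Among the measured compounds shown here, the only measured step, from compound 1 to compound 2, touched the group hanging from that same aromatic ring, and it showed no effect beyond the scatter. It does not directly tell what removing the acetyl altogether and placing a fluorine on the ring will do, so it bears on this step only loosely. For the measured compounds named here, with no step that points either way, compound 3 is expected to sit close to compound 2, with a step of a 1.1-fold higher number from compound 2 to compound 3 (0.05 log units; within the scatter) in this assay that stays within the scatter. The estimate for compound 3 in this assay is 4000 nM, expected to lie between 1300 nM and 12000 nM.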

Compound 3, half-maximal inhibitory concentration: 1810 nM
The estimate for compound 3 lay 2.2-fold (0.34 log units) above the measured number, and the stated range covers the measured number.
By their numbers in this assay, from the lowest: compounds 3, 2 and 1 (each within the scatter of the next, the first and the last beyond it).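

On the carbonyl carbon, the whole aromatic group can be exchanged without any loss in this assay: 2-fluorophenyl in place of 4-acetylphenyl gives a 2.0-fold lower number from compound 2 to compound 3 (0.30 log units; within the scatter), which stays within the scatter, and 2-fluorophenyl in place of 4-(1-hydroxyethyl)phenyl gives a 2.0-fold lower number from compound 1 to compound 3 (0.31 log units; beyond the scatter), a modest step beyond the scatter. The earlier pair only varied the group carried on the ring, whereas these steps show that neither the acetyl nor the 1-hydroxyethyl group is needed to keep this level of activity, and the entering 2-fluorophenyl has no hydrogen-bond acceptor, while 4-acetylphenyl has one. No measurement shown gives a reason for these steps.

Each of these steps removes one group and adds a fluorine in a single move, so the compounds shown cannot tell how much of the difference belongs to either part; a plain phenyl on the carbonyl carbon would separate the two. Going by these compounds, how the number responds to other groups on this ring, such as an amine, a carboxylic acid or a methoxy group, also remains open.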